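Trichlorophenyl in place of chlorophenyl on a shared core

The source may hold more compounds than are shown below. What is called first, only, known or untested is meant among the compounds shown, and "the series" means these compounds.

Going by the values given here, compound 1 `NC1=NC2(CCSCC2)N(OCCCOc2cccc(Cl)c2)C(N)=N1` is the only member of this small set with a number: in a functional assay on MDA-MB-231 cells (Homo sapiens) for antiproliferative activity, read by MTT assay, with a stated time of 72 h (a lower number here means a stronger inhibitor, a higher number a weaker inhibitor), compound 1 gives 130 nM. Compound 2 `CC(C)(C)c1ccc(OCCCON2C(N)=NC(N)=NC23CCOCC3)cc1` carries a different core and a different aromatic group, and in this assay compound 2 gives "not determined" (no result reported), so compound 1 stands alone and cannot be ranked against anything. Compound 3 `NC1=NC2(CCSCC2)N(OCCCOc2cc(Cl)c(Cl)cc2Cl)C(N)=N1` keeps the core of compound 1 and differs in one place only: 2,4,5-trichlorophenyl in place of 3-chlorophenyl on an oxygen on a saturated carbon. Among the compounds with values here, no step between measured compounds is available to calibrate this change, so any expectation rests on compound 1 by itself. The change to 2,4,5-trichlorophenyl is expected to leave the activity close to where compound 1 sits, with a step of a 1.3-fold lower number from compound 1 to compound 3 (0.11 log units; within the scatter) that is expected to stay within the usual scatter or to lean slightly toward stronger inhibition. Compound 3 is therefore estimated at 100 nM in this assay, with a likely range from 40 nM to 300 nM.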

Compound 3, half-maximal inhibitory concentration: 110 nM
The estimate for compound 3 lay 1.1-fold (0.04 log units) below the measured number, within the range that was stated.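

In this assay, going by these compounds alone, replacing 3-chlorophenyl with 2,4,5-trichlorophenyl on the shared core gives the first readable step at this position (a 1.2-fold lower number from compound 1 to compound 3 (0.07 log units; within the scatter)). This place on the chain therefore accepts a ring with three chlorine atoms in place of one, and the antiproliferative read-out does not separate the two compounds. Nothing available accounts for this result.

The compounds shown leave open whether a different kind of group at this place, such as a methoxy group, a trifluoromethyl group, an amine or a carboxylic acid, would move the value beyond the scatter in this assay. They also leave open whether a longer chain carrying the same 2,4,5-trichlorophenyl would preserve the activity of compound 3, which gives 110 nM.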